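Same atoms, joined differently, at compound 2

The compounds below may be only part of what the source reports. "The series", "measured", "known", "first", "only" and "open" are said of these compounds alone.

In a physicochemical assay for lipophilicity, using the shake flask method (a lower number here means a more polar compound, a higher number a more lipophilic compound), compound 1 `Cc1ccc(NC(=O)c2cc(Oc3ccc(S(C)(=O)=O)cc3)cc(OC(C)C)c2)nc1` gives 4.05 and compound 2 `CC(C)Oc1cc(Oc2ccc(S(C)(=O)=O)cc2)cc(-c2cncc(=O)[nH]2)c1` gives 2.27, the lower of the two numbers. Compound 3 `CC(C)Oc1cc(Oc2ccc(S(C)(=O)=O)cc2)cc(-c2nccc(=O)[nH]2)c1` keeps the shared core and carries the same atoms joined differently: a group of 7 heavy atoms (4 carbon, 2 nitrogen, 1 oxygen; one six-membered aromatic ring with 2 hetero atoms) in place of a group of 7 heavy atoms (4 carbon, 2 nitrogen, 1 oxygen; one six-membered aromatic ring with 2 hetero atoms), on an aromatic carbon, on an aromatic carbon of a six-membered aromatic ring of carbon only. Within the data shown here, the sole measured step, a number 1.78 log units lower from compound 1 to compound 2 (beyond the scatter), is large, but it exchanged groups of unequal size, so it bears only indirectly. In this assay the estimated step, a number 0.13 log units higher from compound 2 to compound 3 (within the scatter), is expected to stay within the scatter. The expected value for compound 3 is 2.4, with a range of 1.9 to 2.9.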

Compound 3, distribution coefficient: 2.14
Beside the measured number, compound 3's estimate is 0.26 log units above it; the range from low to high includes it.
By their numbers in this assay, from the lowest: compounds 3 and 2 (each within the scatter of the next); then compound 1.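

Joining the same atoms differently on this aromatic carbon gives a number 0.13 log units lower from compound 2 to compound 3 (within the scatter) in this assay and does not separate the two arrangements in this read-out. Replacing the group of compound 1 with the second arrangement gives a number 1.91 log units lower from compound 1 to compound 3 (beyond the scatter) as a large step, so the large step no longer rests on a single arrangement. No measurement at hand accounts for either step.

Open, going by these compounds, is whether a carboxylic acid or an amine on this aromatic carbon would give a number close to those of compound 2 and compound 3. Also open, on these data alone, is whether a longer chain in place of the isopropoxy group would leave these steps intact.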